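Swapping Trifluoromethyl for Acetyl on a Shared Core

A few compounds are considered here, and "the series" means these few. Any claim that something is new, unique, unknown or untested is made for them only; others in the source may bear on it.

Three compounds share one core and differ only in a single group on the outer six-membered ring. Compound 1 `O/N=C(/Nc1cccc(F)c1)c1ccc2occc2c1` carries fluoro, and in an assay on tissue (HeLa cells) for inhibition of Indoleamine 2,3-dioxygenase 1 (Homo sapiens), read by spectrophotometry (a lower number here means a stronger inhibitor, a higher number a weaker inhibitor), compound 1 gives 20000 nM. Compound 2 `O/N=C(/Nc1cccc(Cl)c1)c1ccc2occc2c1` carries chloro; in this assay compound 2 gives 1500 nM. Compound 3 `O/N=C(/Nc1cccc(C(F)(F)F)c1)c1ccc2occc2c1` carries trifluoromethyl; in this assay compound 3 gives 1900 nM, the second highest of the three numbers, close to compound 2 and far below compound 1. The steps of a 13-fold lower number from compound 1 to compound 2 (1.12 log units; beyond the scatter) and an 11-fold lower number from compound 1 to compound 3 (1.02 log units; beyond the scatter) were large, while a 1.3-fold higher number from compound 2 to compound 3 (0.10 log units; within the scatter) stayed within the scatter. Compound 4 `CC(=O)c1cccc(N/C(=N/O)c2ccc3occc3c2)c1` makes the change (acetyl in place of trifluoromethyl on an aromatic carbon). For the measured compounds named here, no measured step involves acetyl, so for compound 4 only a modest step is expected, a 1.6-fold higher number from compound 3 to compound 4 (0.20 log units; within the scatter), with an estimated 3000 nM in the range 800 nM to 12000 nM.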

Compound 4, half-maximal inhibitory concentration: > 30000 nM
Compound 4: only a limit was reported; the forecaster's own chance of this, stated with the estimate: 5%; middle value at least 10-fold (1.00 log units) away from the limit.
By their numbers in this assay, from the lowest: compounds 2 and 3 (each within the scatter of the next); then compound 1. At a limit, above all of these: compound 4.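

On this aromatic carbon, acetyl does not match chloro or trifluoromethyl, the two groups that gave the lowest numbers: the steps are an at least 15-fold higher number from compound 3 to compound 4 (1.19 log units; beyond the scatter) and an at least 20-fold higher number from compound 2 to compound 4 (1.30 log units; beyond the scatter), both large. In this assay compound 4 gives > 30000 nM, which is a limit of the assay and not a number. Against fluoro the reading is looser, with an at least 1.5-fold higher number from compound 1 to compound 4 (0.17 log units; that floor lies within the scatter), so this pair stays unseparated.

Going by these compounds, whether an amine or a carboxylic acid at this place would fall with chloro and trifluoromethyl or with acetyl stays open. On these data alone, the true value of compound 4 also stays open.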